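This account rests on a few compounds, and the source may have more. Where it says the series, first, only, none or still open, it means among the compounds named here.

Compound 1 `Cc1cccc(Cn2c(N)nc3cc(Cl)c(Cl)cc32)c1`: 48000 nM
Compound 2 `Nc1nc2cc(Cl)c(Cl)cc2n1Cc1ccc([N+](=O)[O-])cc1`: 32000 nM

Within the data shown here, only two compounds have been measured so far in a functional assay on CEM-SS cells (Homo sapiens) for cytotoxicity; a higher number here means a weaker inhibitor, a lower number a stronger inhibitor. There, compound 1 gives 48000 nM. This number stands within the usual scatter of the value for compound 2, so neither compound can be ranked above the other.

The next compound is compound 3 `Nc1nc2cc(Cl)c(Cl)cc2n1Cc1cccc([N+](=O)[O-])c1`, which keeps the core of compound 1 and has nitro in place of methyl on an aromatic carbon, meta to a large group: nitro in place of methyl on an aromatic carbon. Among the measured compounds shown here, no measured pair of compounds isolates this change, so its size cannot be read directly from the data. The nearest guide is compound 2, which also carries a nitro group, though at a different place, and gives 32000 nM. That value offers no sign of a shift away from compound 1, so no change beyond the scatter is expected in this assay. The expected step is a 1.3-fold lower number from compound 1 to compound 3 (0.12 log units; within the scatter), which is small and has no firmly expected direction. For compound 3 the estimated value is 36000 nM, with an expected range of 18000 nM to 70000 nM.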

Compound 3, half-maximal inhibitory concentration: 47000 nM
Compound 3: middle estimate off by 1.3-fold (0.12 log units), on the low side, and the stated range covers the measured number.
By their numbers in this assay, from the lowest: compounds 2, 3 and 1 (each within the scatter of the next).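

In this assay the exchange of methyl for nitro on this aromatic carbon, meta to a large group, amounts to a 1.0-fold lower number from compound 1 to compound 3 (0.01 log units; within the scatter) and leaves the two compounds within the scatter of each other. Among these compounds, this pair isolates the change for the first time, which the comparison of compound 1 with compound 2 could not do, since their groups sit at different places. At this position, then, the number does not distinguish methyl from nitro, even though nitro is the larger group and brings hydrogen-bond acceptors that methyl lacks, and no measurement at hand accounts for this result.

The compounds shown leave open whether any other group at this position, such as an amine, a carboxylic acid or a longer chain, would move the number beyond the scatter. They also leave open whether the two chlorines or the amine on the shared core matter here, since all three compounds carry them unchanged.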